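Shortening the ester side chain of compound 3

A few compounds are considered here, and "the series" means these few. Any claim that something is new, unique, unknown or untested is made for them only; others in the source may bear on it.

In an in vitro ADME assay on the whole organism (small intestine) for pharmacokinetics, with Rattus norvegicus as the target (on this read-out higher numbers stand for a longer-lived compound and lower numbers for a shorter-lived compound), compound 3 `C=CCN(CCCC(=O)OCC)C(=O)/C(C)=C/c1ccc(C(=O)Oc2ccc(C(=N)N)cc2)cc1` gives 1 h. This is level, within the usual scatter, with compound 1 `C=CCN(CCCC(=O)O)C(=O)/C(C)=C/c1ccc(C(=O)Oc2ccc(C(=N)N)cc2)cc1` at 0.917 h and compound 2 `C/C(=C\c1ccc(C(=O)Oc2ccc(C(=N)N)cc2)cc1)C(=O)N(CC(=O)O)C1CCCCC1` at 0.817 h. Compound 4 `C=CCN(CCC(=O)OCC)C(=O)/C(C)=C/c1ccc(C(=O)Oc2ccc(C(=N)N)cc2)cc1` carries 2-(ethoxycarbonyl)ethyl where compound 3 carries 3-(ethoxycarbonyl)propyl: ethoxycarbonyl in place of (ethoxycarbonyl)methyl on a saturated chain carbon, two bonds along the chain from an amide-type nitrogen. Among the measured compounds shown here, no measured step makes this exact change. The two closest are a 1.1-fold higher number from compound 1 to compound 3 (0.04 log units; within the scatter) and a 1.1-fold lower number from compound 1 to compound 2 (0.05 log units; within the scatter), and the second of these also alters this side chain. Both stay within the scatter, so no step beyond it is expected in this assay. The estimated step is a 1.1-fold lower number from compound 3 to compound 4 (0.02 log units; within the scatter). For compound 4 the expected half-life is 0.95 h, with an estimated range of 0.55 h to 1.6 h.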

Compound 4, half-life: 1 h
Compound 4: middle estimate off by 1.1-fold (0.02 log units), on the low side; measured number inside the range.
By their numbers in this assay, from the lowest: compounds 2, 1, 3 and 4 (each within the scatter of the next).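

In this assay, 2-(ethoxycarbonyl)ethyl in place of 3-(ethoxycarbonyl)propyl gives no change at the digits printed from compound 3 to compound 4 (within the scatter) and shows that this ester chain can be shortened with no readable effect on half-life. The steps from the two carboxylic acids, a 1.1-fold higher number from compound 1 to compound 4 (0.04 log units; within the scatter) and a 1.2-fold higher number from compound 2 to compound 4 (0.09 log units; within the scatter) also stay within the scatter, so the shorter ester does not separate from either acid here.

Nothing measured here accounts for this flat result. Going by these compounds, whether a longer chain, or an amine at the chain end, would also leave the half-life level remains open.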